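Removing the methoxy group: an expectation for compound 3

This account rests on a few compounds, and the source may have more. Where it says the series, first, only, none or still open, it means among the compounds named here.

Measured compounds:
Compound 1 `Fc1ccc(C2=NN(C3=NC(c4ccccc4)CS3)C(c3ccc4ccccc4c3)C2)cc1` gives 17300 nM in a functional assay on BGC-823 cells (Homo sapiens) for inhibition, read by CCK-8 assay, with a stated time of 48 h; on this read-out higher numbers stand for weaker inhibition and lower numbers for stronger inhibition.
Compound 2 `COc1ccc(C2=NN(C3=NC(c4ccccc4)CS3)C(c3ccc4ccccc4c3)C2)cc1` gives 7250 nM in this assay.

For the measured compounds named here, compound 2 stands at the lowest of the two numbers measured so far, meaning the stronger inhibition of the pair. Going by the values given here, the single step that connects the two, a 2.4-fold lower number from compound 1 to compound 2 (0.38 log units; beyond the scatter), is the only measured change, and it goes beyond the usual scatter of this assay.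

Compound 3 `c1ccc(C2=NN(C3=NC(c4ccccc4)CS3)C(c3ccc4ccccc4c3)C2)cc1` is not yet measured. It differs from compound 2 by hydrogen in place of methoxy on an aromatic carbon. Among the compounds with values here, this change has no direct counterpart in the measured steps: the only one available, a 2.4-fold lower number from compound 1 to compound 2 (0.38 log units; beyond the scatter), swaps fluoro for methoxy at that same aromatic carbon, which shows that this position is sensitive to what sits there, but it does not show what a hydrogen alone does. Within the data shown here, with only that step to go by, the expected outcome is a small move, possibly in either direction, and not clearly beyond the scatter. The estimate for compound 3 is therefore 11000 nM, in a range from 4000 nM to 30000 nM, which corresponds to an expected step of a 1.5-fold higher number from compound 2 to compound 3 (0.18 log units; within the scatter).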

Compound 3, half-maximal inhibitory concentration: 9620 nM
The estimate for compound 3 lay 1.1-fold (0.06 log units) above the measured number; the range from low to high includes it.
By their numbers in this assay, from the lowest: compounds 2, 3 and 1 (each within the scatter of the next, the first and the last beyond it).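

Taking the methoxy group away, so that 4-methoxyphenyl becomes phenyl, gives a 1.3-fold higher number from compound 2 to compound 3 (0.12 log units; within the scatter) in this assay and leaves compound 2 and compound 3 indistinguishable on this read-out. Putting hydrogen in place of fluoro gives a 1.8-fold lower number from compound 1 to compound 3 (0.25 log units; within the scatter) and is likewise too small to count as a real difference. Compound 3 therefore lies within the scatter of both neighbours, and the only difference at this aromatic carbon that stands out is the one between the two substituted compounds, a 2.4-fold lower number from compound 1 to compound 2 (0.38 log units; beyond the scatter), which hydrogen alone does not reproduce from either side. Nothing available here explains why the numbers at this position fall as they do.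

On these data alone, with only fluoro, hydrogen and methoxy at this carbon, it remains open whether a group of a different kind, such as an amine or a carboxylic acid, would move the number clearly away from that of compound 3. As far as these compounds go, it is also open whether a longer chain, such as ethoxy in place of methoxy, would widen the gap to compound 1 or leave it unchanged.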